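Second trifluoromethyl on the ether ring: two anilide cores

A few compounds are considered here, and "the series" means these few. Any claim that something is new, unique, unknown or untested is made for them only; others in the source may bear on it.

Measured so far:
compound 1, `CC(O)(COc1cccc(C(F)(F)F)c1)C(=O)Nc1ccc(S(F)(F)(F)(F)F)cc1`, 14600 nM in a functional assay on CWR22R cells (Homo sapiens) for antiproliferative activity, read by propidium iodide staining, with a stated time of 96 h; on this read-out higher numbers stand for weaker inhibition and lower numbers for stronger inhibition
compound 2, `CC(O)(COc1cc(C(F)(F)F)cc(C(F)(F)F)c1)C(=O)Nc1ccc(S(F)(F)(F)(F)F)cc1`, 7000 nM
compound 3, `CC(O)(COc1cccc(C(F)(F)F)c1)C(=O)Nc1cccc(S(F)(F)(F)(F)F)c1`, 28900 nM

Compound 3 shares its atoms with compound 1, joined differently; the difference between the two cores is not broken down here. Their values lie within the scatter of each other.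

From compound 1 to compound 2 the change is trifluoromethyl in place of hydrogen on an aromatic carbon, and it gave a 2.1-fold lower number from compound 1 to compound 2 (0.32 log units; beyond the scatter) in this assay.

Compound 4, `CC(O)(COc1cc(C(F)(F)F)cc(C(F)(F)F)c1)C(=O)Nc1cccc(S(F)(F)(F)(F)F)c1`, is not yet measured. From compound 3 to compound 4 the change is trifluoromethyl in place of hydrogen on an aromatic carbon, the same change, at a place described in the same words.

For the measured compounds named here, the step expected from compound 3 to compound 4 is a 2.1-fold lower number from compound 3 to compound 4 (0.31 log units; beyond the scatter) in this assay, matching the single earlier step, because a 2.1-fold lower number from compound 1 to compound 2 (0.32 log units; beyond the scatter) is the only guide at hand. Compound 4 is therefore estimated at 14000 nM, between 6500 nM and 30000 nM.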

Compound 4, half-maximal inhibitory concentration: 6500 nM
Compound 4: middle estimate off by 2.2-fold (0.33 log units), on the high side; low and high end bracket the measured number.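

In this assay the second trifluoromethyl again gave a 4.4-fold lower number from compound 3 to compound 4 (0.65 log units; beyond the scatter) and so lowered the number on both cores. The two steps cannot be told apart in size: the same change on two cores in this assay, a 2.1-fold lower number (0.32 log units; beyond the scatter) from compound 1 to compound 2 and a 4.4-fold lower number (0.65 log units; beyond the scatter) from compound 3 to compound 4, 2.1-fold (0.33 log units) apart, within the scatter of two such steps. For the compounds shown here, this supports carrying the change between these two cores in this assay, but with only two pairs it does not show that the step would hold on a further core or explain how the change acts.

On these data alone, whether a smaller or larger group at the same ring carbon, such as a chlorine, a nitrile or a methoxy group, would give a similar step remains open. Also open, as far as these compounds go, is whether an amine or a carboxylic acid on the ether ring would be tolerated on either core.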